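The source may hold more compounds than are shown below. What is called first, only, known or untested is meant among the compounds shown, and "the series" means these compounds.

Compound 1 `O=C(OC1CCC(CN2CCN(c3cc(=O)c4cc(C(F)(F)F)cc([N+](=O)[O-])c4s3)CC2)CC1)c1ccncc1`: 0.0817 h
Compound 2 `CC(=O)OC1CCC(CN2CCN(c3cc(=O)c4cc(C(F)(F)F)cc([N+](=O)[O-])c4s3)CC2)CC1`: < 0.15 h

In an ADME assay on cells (Hepatocyte, Mus musculus) for metabolic stability (on this read-out lower numbers stand for a shorter-lived compound and higher numbers for a longer-lived compound), compound 1 gives 0.0817 h, a true number. Compound 2 has only < 0.15 h, which is a limit of the assay and not a number. This is the limit of < 0.15 h in this assay, at which 1 of the 2 values shown sits.

Compound 3 `O=C(OC1CCC(CN2CCN(c3cc(=O)c4cc(C(F)(F)F)cc([N+](=O)[O-])c4s3)CC2)CC1)c1ccc(C(F)(F)F)cc1` has 4-(trifluoromethyl)phenyl in place of methyl on a carbonyl carbon. Among the compounds with values here, the one measured step at this place is a step that the limit leaves unreadable from compound 1 to compound 2, so it offers no size to carry over. The nearest guide is compound 1, which has pyridin-4-yl at that carbonyl carbon, a six-membered aromatic ring as well, and gives 0.0817 h. No clear step in either direction is therefore expected in this assay. The estimate amounts to a step that the limit leaves unreadable from compound 2 to compound 3. Compound 3 is expected at about 0.1 h, with an estimated range of 0.05 h to 0.25 h.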

Compound 3, half-life: 0.278 h
Beside the measured number, compound 3's estimate is 2.8-fold (0.44 log units) below it, and the stated range ends below it.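

In this assay, the group on this carbonyl carbon can clearly shift the half-life, and two six-membered aromatic rings there need not behave alike: the change gives a 3.4-fold higher number from compound 1 to compound 3 (0.53 log units; beyond the scatter). Measured against methyl, the same group gives an at least 1.8-fold higher number from compound 2 to compound 3 (0.26 log units; that floor lies within the scatter), so only a floor can be read and it does not yet separate the two compounds. Compound 2 has a limit and not a number, so the step from compound 1 to compound 2 cannot be read either: the limit of < 0.15 h in this assay, at which 1 of the 3 values shown sits.

From the compounds shown here alone, it remains open whether the longer half-life comes from the trifluoromethyl group or from the all-carbon ring that carries it, a question that plain phenyl at this place could help settle. Going by these compounds, how a saturated ring such as cyclohexyl would fare on the same carbonyl carbon is also open.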